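Thiophene-fused core series: swapping the ketone aryl group

A few compounds are considered here, and "the series" means these few. Any claim that something is new, unique, unknown or untested is made for them only; others in the source may bear on it.

Measured so far in a functional assay on CHO-K1 cells for antagonist activity at adenosine receptor A2b (Homo sapiens), read by FLIPR and calcium flux; on this read-out higher numbers stand for weaker inhibition and lower numbers for stronger inhibition:
compound 1 `CCc1nc(C(=O)c2ccc(C)s2)c2sccc2n1` gives 3670 nM
compound 2 `Cc1ccc(C(=O)c2nc(NC(=O)c3cccnc3)nc3ccsc23)s1` gives 287 nM
compound 3 `O=C(c1ccc(Cl)s1)c1nc(NCc2cccnc2)nc2ccsc12` gives 487 nM

Compound 3 sits second highest of the three numbers in this assay. Its neighbour is compound 2, whose value lies within the scatter of that of compound 3, so the two cannot be told apart. Compound 1 stands well beyond the scatter, a clearly higher number than compound 3.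

Compound 4 `O=C(c1cccnc1)c1nc(NCc2cccnc2)nc2ccsc12` differs from compound 3 in one place: pyridin-3-yl in place of 5-chlorothiophen-2-yl on a carbonyl carbon. For the measured compounds named here, no measured pair shows this exchange, so nothing in the shared core or the other arm of compound 3 says which way it goes. The step from compound 3 to compound 4 is expected to be modest, towards a somewhat higher number, with no change beyond the scatter just as likely: a 1.8-fold higher number from compound 3 to compound 4 (0.27 log units; within the scatter). Compound 4 is therefore estimated at 900 nM, within 250 nM to 3500 nM.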

Compound 4, half-maximal inhibitory concentration: 109 nM
The estimate for compound 4 lay 8.3-fold (0.92 log units) above the measured number; measured number below the stated range.
By their numbers in this assay, from the lowest: compound 4; then compounds 2 and 3 (each within the scatter of the next); then compound 1.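

In this assay, pyridin-3-yl in place of 5-chlorothiophen-2-yl on a carbonyl carbon gives a 4.5-fold lower number from compound 3 to compound 4 (0.65 log units; beyond the scatter) with the other arm unchanged. This single exchange shows that the aryl group on the carbonyl moves the read-out and that the chlorinated five-membered ring is not needed here for a lower number. Nothing available explains the size or direction of this step. Open, from the compounds shown here alone, is whether phenyl, pyridin-2-yl or pyridin-4-yl on the same carbonyl goes the same way. Also open, going by these compounds, is whether pyridin-3-yl gives a similar step with the other arm of compound 2.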